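Ethyl in Place of Hydrogen: Three Limits and a Fourth

The compounds below may be only part of what the source reports. "The series", "measured", "known", "first", "only" and "open" are said of these compounds alone.

Compound 1, `CC(C)N(Cc1cccc(OCCCCCC(=O)O)c1)C(=O)c1ccc(-c2cccc(Oc3ccccc3)c2)cc1`, gives a limit of > 18700 nM.
Compound 2, `CC(C)N(Cc1cccc(OCCCCCC(=O)O)c1)C(=O)c1ccc(-c2cc3ccccc3n2S(=O)(=O)c2ccccc2)cc1`, gives a limit of > 26000 nM.
Compound 3, `CCOC(=O)CCCCCOc1cccc(CN(C(=O)c2ccc(-c3cccc(Oc4ccccc4)c3)cc2)C(C)C)c1`, gives a limit of > 19600 nM.

All three readings come from an ADME assay on BJ cells (Homo sapiens) for cytotoxicity, read by CellTiter-Glo and resazurin assay, with a stated time of 72 h (a lower number here means that less compound is needed, a higher number that more compound is needed for the effect), and each of them is a limit of the assay rather than a number. Compound 1 and compound 3 differ in one place: ethyl in place of hydrogen on an oxygen next to a carbonyl group. The two limits leave the step that the two limits leave unreadable from compound 1 to compound 3 from one to the other unreadable. Compound 2 shares the amide and the acid side chain of compound 1 but carries a different core; the difference between the two cores is not broken down here.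

Compound 4, `CCOC(=O)CCCCCOc1cccc(CN(C(=O)c2ccc(-c3cc4ccccc4n3S(=O)(=O)c3ccccc3)cc2)C(C)C)c1`, has not yet been measured. Among the measured compounds shown here, it differs from compound 2 by ethyl in place of hydrogen on an oxygen next to a carbonyl group, the same change as the one from compound 1 to compound 3, the place being described in the same words in both cases. Compound 1 sits at the limit of > 18700 nM in this assay, at which 1 of the 3 values shown sits. Compound 3 sits at the limit of > 19600 nM in this assay, at which 1 of the 3 values shown sits. Compound 2 sits at the limit of > 26000 nM in this assay, at which 1 of the 3 values shown sits. With all three at limits there is no measured size to carry over. The step from compound 2 to compound 4 is expected to be a step that the limit leaves unreadable from compound 2 to compound 4, that is, no readable movement. Compound 4 is expected to give 30000 nM, most probably again as a limit. The expected range for compound 4 runs from 15000 nM to 80000 nM.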

Compound 4, half-maximal effective concentration: > 26000 nM
Compound 4 ended at the assay's limit; the forecaster's own chance of this, stated with the estimate: 85%; the middle value is on the limit's open side.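

Compound 2 and compound 4 both end at a limit of the assay rather than at a number, and no size can be read for the step from one to the other. The compounds shown leave open how much of any of them is needed for the effect, and whether ethyl in place of hydrogen on an oxygen next to a carbonyl group changes that amount at all.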